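Swapping the aryl hydrazone arm: compound 3 to compound 4

This account rests on a few compounds, and the source may have more. Where it says the series, first, only, none or still open, it means among the compounds named here.

Three analogues share one core and differ only in the aryl group on the hydrazone carbon. Compound 1 `CN(C)CCn1cnnc1-c1cc(Oc2ccc(NC(=O)N/N=C/c3cccc(Cl)c3Cl)cc2F)ccn1` gives 1090 nM in a functional assay on A549 cells (Homo sapiens) for cytotoxicity, read by MTT assay, with a stated time of 72 h (a higher number here means a weaker inhibitor, a lower number a stronger inhibitor), compound 2 `CN(C)CCn1cnnc1-c1cc(Oc2ccc(NC(=O)N/N=C/c3cc(C(C)(C)C)cc(C(C)(C)C)c3O)cc2F)ccn1` gives 980 nM, and compound 3 `CN(C)CCn1cnnc1-c1cc(Oc2ccc(NC(=O)N/N=C/c3c(O)ccc4ccccc34)cc2F)ccn1` gives 880 nM. Compound 3 holds the lowest of the three numbers, but its gaps to compound 2 and to compound 1 are both within the scatter, so no order can be claimed. Within the data shown here, the one relevant step, a 1.2-fold lower number from compound 1 to compound 3 (0.09 log units; within the scatter), was itself within the scatter. Compound 4 `CN(C)CCn1cnnc1-c1cc(Oc2ccc(NC(=O)N/N=C/c3c(Cl)cccc3Cl)cc2F)ccn1` carries the change (2,6-dichlorophenyl in place of 2-hydroxynaphthalen-1-yl on a carbon with a double bond to nitrogen). Because compound 1 with its dichlorophenyl gave 1090 nM, a step of about a 1.1-fold higher number from compound 3 to compound 4 (0.06 log units; within the scatter) is expected, with no shift beyond the scatter. Compound 4 is therefore estimated at 1000 nM, between 500 nM and 2100 nM.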

Compound 4, half-maximal inhibitory concentration: 1410 nM
Beside the measured number, compound 4's estimate is 1.4-fold (0.15 log units) below it; low and high end bracket the measured number.
By their numbers in this assay, from the lowest: compounds 3, 2, 1 and 4 (each within the scatter of the next).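

In this assay, 2,6-dichlorophenyl in place of 2-hydroxynaphthalen-1-yl on this carbon, a swap that removes one aromatic ring along with the hydrogen-bond donor and acceptor, gave a 1.6-fold higher number from compound 3 to compound 4 (0.20 log units; within the scatter) and so did not separate the two compounds. The two chlorines also changed places without separating compounds, with a 1.3-fold higher number from compound 1 to compound 4 (0.11 log units; within the scatter) as the step from the 2,3-dichlorophenyl analogue. No measurement bears on the reason for these results. The compounds shown leave open whether an amine, a carboxylic acid or a cyclohexyl group on this carbon would give a step beyond the scatter.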